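Demethylation on the pyranone ring across two cores

The source may hold more compounds than are shown below. What is called first, only, known or untested is meant among the compounds shown, and "the series" means these compounds.

Measured so far in a functional assay on MDA-MB-231 cells (Homo sapiens) for cytotoxicity, read by MTT assay; a higher number here means a weaker inhibitor, a lower number a stronger inhibitor:
compound 1 `Cc1oc2c3c(ccc2c(=O)c1C)OC[C@H]1[C@@H]3c2c(ccc(C(=O)c3ccccc3)c2O)OC1(C)C`: > 100000 nM
compound 2 `Cc1coc2c3c(ccc2c1=O)OC[C@H]1[C@@H]3c2c(ccc(C(=O)c3ccccc3)c2O)OC1(C)C`: 5680 nM
compound 3 `Cc1oc2c3c(ccc2c(=O)c1C)OC[C@H]1[C@@H]3c2ccc3ccccc3c2OC1(C)C`: > 100000 nM

Compound 1 gives only a limit in this assay, > 100000 nM. Compound 2 gives 5680 nM. The step of an at least 17-fold lower number from compound 1 to compound 2 (1.24 log units; beyond the scatter) is large and rests on a single change: hydrogen in place of methyl on an aromatic carbon.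

Compound 3 also gives only a limit, > 100000 nM. Two of the three values sit at the limit of > 100000 nM in this assay, at which 2 of the 3 values shown sit, so the width of the step from compound 1 to compound 2 is itself only a lower bound. How the core of compound 3 differs from that of compound 1 is not broken down here.

Compound 4 `Cc1coc2c3c(ccc2c1=O)OC[C@H]1[C@@H]3c2ccc3ccccc3c2OC1(C)C` is not yet measured. Its relation to compound 3 is hydrogen in place of methyl on an aromatic carbon. This is the same kind of change as from compound 1 to compound 2, though the ring here is part of a fused or bridged system of six rings rather than five. On the basis of the step from compound 1 to compound 2, a step of an at least 5.0-fold lower number from compound 3 to compound 4 (0.69 log units; beyond the scatter) is expected from compound 3 to compound 4, with the caveat that compound 3 is a limit. Compound 4 is therefore estimated at 20000 nM, between 3000 nM and 120000 nM.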

Compound 4, half-maximal inhibitory concentration: > 100000 nM
Compound 4: only a limit was reported; the forecaster's own chance of this, stated with the estimate: 35%; middle value at least 5.0-fold (0.69 log units) from the limit.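

Compound 4 gives only a limit in this assay, > 100000 nM. Within the data shown here, compound 3 is also only a limit, so no step between compound 3 and compound 4 can be read. The compounds shown leave open whether hydrogen in place of methyl changes anything on the core of compound 3, as it does on the core of compound 1.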